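Trifluoromethyl on compound 2: growth inhibition notes

This account rests on a few compounds, and the source may have more. Where it says the series, first, only, none or still open, it means among the compounds named here.

Of the compounds shown here, two have been measured so far in a functional assay on ZR-75-1 cells (Homo sapiens) for inhibition, read by sulforhodamine B assay; on this read-out lower numbers stand for stronger inhibition of growth and higher numbers for weaker inhibition of growth. Compound 1 `FC(F)(F)c1ccc(-c2ccc(-c3ccc(-c4nc5ccccc5[nH]4)cc3)cc2)cc1` gives 48300 nM, and compound 2 `Cc1ccc2[nH]c(-c3ccc(-c4ccc(-c5ccccc5)cc4)cc3)nc2c1` gives 27400 nM. These two values lie within the scatter of each other, so compound 2 stands level with compound 1 on the numbers available. Among the measured compounds shown here, both sit in the same micromolar-range region of the read-out, and the two compounds do not differ in one place only, so they offer no direct measured step.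

The next compound is compound 3 `Cc1ccc2[nH]c(-c3ccc(-c4ccc(-c5ccc(C(F)(F)F)cc5)cc4)cc3)nc2c1`, not yet measured. It derives from compound 2 by trifluoromethyl in place of hydrogen on an aromatic carbon, para to a large group, which turns phenyl into 4-(trifluoromethyl)phenyl. Compound 1 also carries the 4-(trifluoromethyl)phenyl group and gives 48300 nM, so no large change is anticipated. The expected outcome is a 1.3-fold higher number from compound 2 to compound 3 (0.11 log units; within the scatter), which would be no change beyond the scatter. For compound 3 the estimated value is 35000 nM, with an expected range of 15000 nM to 80000 nM.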

Compound 3, concentration for 50% growth inhibition: 2410 nM
Beside the measured number, compound 3's estimate is 15-fold (1.16 log units) above it; measured number below the stated range.
By their numbers in this assay, from the lowest: compound 3; then compounds 2 and 1 (each within the scatter of the next).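

Notes on the result: in this assay, trifluoromethyl in place of hydrogen on an aromatic carbon, para to a large group, gives an 11-fold lower number from compound 2 to compound 3 (1.06 log units; beyond the scatter) when the methyl is present, so this position responds strongly to the change from phenyl to 4-(trifluoromethyl)phenyl, which compound 1 and compound 2 could not show on their own. Methyl in place of hydrogen on an aromatic carbon gives a 20-fold lower number from compound 1 to compound 3 (1.30 log units; beyond the scatter) with 4-(trifluoromethyl)phenyl in place, so the methyl also matters in this setting, even though compound 1 and compound 2, each carrying only one of the two groups, lie within the scatter of each other; among the compounds shown, only compound 3 carries both groups and only compound 3 stands apart. No measurement at hand bears on the reason for these steps.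

Going by these compounds, whether the gain belongs to trifluoromethyl in particular stays open, and chlorine, a nitrile or an amine at the same place would help to settle it. On these data alone, whether the methyl can be exchanged is also open, and an ethyl group or a carboxylic acid in its place would test how closely the two groups depend on each other.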